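Solubility notes: five-membered ring variation on the shared core

The source may hold more compounds than are shown below. What is called first, only, known or untested is meant among the compounds shown, and "the series" means these compounds.

Measured compounds:
compound 1 `CC(C)C(Nc1nccs1)c1ccc(-c2ccc3cccc(F)c3c2)[nH]c1=O` gives 16100 nM
compound 2 `CC(C)C(c1ccc(-c2ccc3cccc(F)c3c2)[nH]c1=O)N1CCN/C1=N\C#N` gives 25200 nM
compound 3 `CC(C)C(Cc1noc(=O)[nH]1)c1ccc(-c2ccc3cccc(F)c3c2)[nH]c1=O` gives 30400 nM

In a physicochemical assay for solubility, in phosphate buffer, measured as kinetic solubility (on this read-out lower numbers stand for lower solubility and higher numbers for higher solubility), compound 3 sits within the scatter of both neighbours: a 1.9-fold higher number from compound 1 to compound 3 (0.28 log units; within the scatter) and a 1.2-fold higher number from compound 2 to compound 3 (0.08 log units; within the scatter). Compound 4 `CC(C)C(Cc1nnc[nH]1)c1ccc(-c2ccc3cccc(F)c3c2)[nH]c1=O` is not yet measured. It differs from compound 3 by a group of 5 heavy atoms (2 carbon, 3 nitrogen; one five-membered aromatic ring with 3 hetero atoms) in place of a group of 6 heavy atoms (2 carbon, 2 nitrogen, 2 oxygen; one five-membered aromatic ring with 3 hetero atoms), on a saturated chain carbon, two bonds along the chain from an aromatic carbon. All three measured steps exchange a five-membered ring at the same position of the shared core, and none moved the number beyond the scatter, a 1.6-fold higher number from compound 1 to compound 2 (0.19 log units; within the scatter) included. The step to compound 4 is of the same kind, so no change beyond the scatter is expected, with a 1.2-fold lower number from compound 3 to compound 4 (0.08 log units; within the scatter) as the estimated step. Compound 4 is therefore expected at 25000 nM, within a range of 12000 nM to 50000 nM.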

Compound 4, solubility: 24200 nM
Beside the measured number, compound 4's estimate is 1.0-fold (0.01 log units) above it; the range from low to high includes it.
By their numbers in this assay, from the lowest: compounds 1, 4, 2 and 3 (each within the scatter of the next).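

In (this assay), 4H-1,2,4-triazol-3-yl on a saturated chain carbon, two bonds along the chain from an aromatic carbon, stays within the scatter on each step: (a 1.3-fold lower number from compound 3 to compound 4 (0.10 log units; within the scatter)), (a 1.0-fold lower number from compound 2 to compound 4 (0.02 log units; within the scatter)) and (a 1.5-fold higher number from compound 1 to compound 4 (0.18 log units; within the scatter)). A ring with nitrogen as its only hetero atom thus joins the set, and the four compounds still do not separate. Nothing on hand accounts for this.

On these data alone, whether an amine or a carboxylic acid at this place, or a longer chain, would move the number beyond the scatter stays open.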